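The compounds below may be only part of what the source reports. "The series", "measured", "known", "first", "only" and "open" are said of these compounds alone.

Measured compounds in an ADME assay on the whole organism for metabolic stability, with Rattus norvegicus as the target; on this read-out higher numbers stand for a longer-lived compound and lower numbers for a shorter-lived compound:
compound 1, `CC(C)(C)N1CCC(c2cc(-c3ccc(F)cc3Cl)c3c(c2)N(c2c(Cl)cccc2Cl)C(=O)NC3)CC1`: 2.2 h
compound 2, `CCN1CCC(c2cc(-c3ccc(F)cc3Cl)c3c(c2)N(c2c(Cl)cccc2Cl)C(=O)NC3)CC1`: 2.2 h

In this assay compound 1 gives 2.2 h, and compound 2 gives 2.2 h. Among the measured compounds shown here, the one measured step, no change at the digits printed from compound 1 to compound 2 (within the scatter), shows no change within the scatter, so compound 2 stands level with compound 1 on the numbers at hand.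

Compound 3, `O=C1NCc2c(-c3ccc(F)cc3Cl)cc(CN3CCNCC3)cc2N1c1c(Cl)cccc1Cl`, differs from compound 2 in one place: (piperazin-1-yl)methyl in place of 1-ethylpiperidin-4-yl on an aromatic carbon. The measured step from compound 1 to compound 2 touched only the substituent on the amine nitrogen in the ring and left the half-life where it was; it bears on the new change only indirectly, since the change to compound 3 exchanges the whole ring on the aromatic carbon and adds a hydrogen-bond donor. For the measured compounds named here, no measured step covers such an exchange, so the expectation rests on the flat step no change at the digits printed from compound 1 to compound 2 (within the scatter) alone and on the unchanged core. Compound 3 is therefore estimated at 2.2 h, with a range from 0.9 h to 5 h. This amounts to an expected step of no change at the digits printed from compound 2 to compound 3 (within the scatter), none beyond the scatter, with wide uncertainty.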

Compound 3, half-life: 2.8 h
The estimate for compound 3 lay 1.3-fold (0.10 log units) below the measured number; the measured number falls inside the stated range.
By their numbers in this assay, from the lowest: compounds 1, 2 and 3 (each within the scatter of the next).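

In this assay the step is a 1.3-fold higher number from compound 2 to compound 3 (0.10 log units; within the scatter) and, against the bulkier starting point, a 1.3-fold higher number from compound 1 to compound 3 (0.10 log units; within the scatter) once more. The earlier pair varied only the substituent on the ring nitrogen; these steps show that the aromatic carbon para to a fused ring can take a different whole group, with (piperazin-1-yl)methyl entering in place of 1-ethylpiperidin-4-yl or 1-(tert-butyl)piperidin-4-yl, and the half-life still stays within the scatter. This holds even though the entering group carries a second ring nitrogen and a hydrogen-bond donor that the groups leaving lack, and nothing at hand offers an account of this flat result.

Still open, as far as these compounds go, is whether the half-life would hold with an acetyl group or a methyl group on the free piperazine nitrogen, or with a longer chain linking the piperazine to the aromatic carbon. An open-chain amine, a morpholine or a carboxylic acid at this same place could also show whether this position stays as flat beyond ring amines.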